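The source may report more compounds than this note shows. Statements on the series, on what has been measured and on what is new or still open speak of the compounds shown alone.

Compound 2 `Cc1ccc2ncc(S(=O)(=O)c3cc(Cl)cc(Cl)c3)c(N3CCC(C)CC3)c2c1` stands second highest of the three measured compounds in an assay on isolated protein for displacement of a labelled ligand from metabotropic glutamate receptor 5 (Homo sapiens), with a stated time of 60 min, tested at 1 uM (a lower number here means less inhibition, a higher number more inhibition at the concentration tested (going by the name of the read-out)), where compound 2 gives 75%. Compound 3 `CC1CCN(c2c(S(=O)(=O)c3cc(Cl)cc(Cl)c3)cnc3ccc(Cl)cc23)CC1` gives 88%, and the step of a number 13 percentage points higher from compound 2 to compound 3 (beyond the scatter) came from chloro in place of methyl on an aromatic carbon. Compound 1 `Cc1ccc2ncc(S(=O)(=O)c3ccc(C#N)cc3)c(N3CCC(C)CC3)c2c1` gives 55%; the step of a number 20 percentage points higher from compound 1 to compound 2 (beyond the scatter) came from 3,5-dichlorophenyl in place of 4-cyanophenyl on a sulfonyl sulfur. Compound 4 `Cc1cc(C)cc(S(=O)(=O)c2cnc3ccc(C)cc3c2N2CCC(C)CC2)c1` differs from compound 2 on that same sulfonyl sulfur: 3,5-dimethylphenyl in place of 3,5-dichlorophenyl on a sulfonyl sulfur. For the measured compounds named here, only the step from compound 1 to compound 2 concerns the group on this sulfur, and it measured a different exchange, so no measured step shows directly how 3,5-dimethylphenyl compares with 3,5-dichlorophenyl. For compound 4 the expected step is a number 10 percentage points lower from compound 2 to compound 4 (within the scatter), a modest fall or one within the scatter. Compound 4 is thus expected to give about 65%, between 45% and 85%.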

Compound 4, a percentage reported as inhibition, at one concentration (the size of the read-out at that concentration, not a potency): 80%
Estimate against measurement, compound 4: 15 percentage points below, and the stated range covers the measured number.
By their numbers in this assay, from the lowest: compound 1; then compounds 2, 4 and 3 (each within the scatter of the next, the first and the last beyond it).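

On the sulfonyl sulfur, 3,5-dimethylphenyl in place of 3,5-dichlorophenyl gives a number 5 percentage points higher from compound 2 to compound 4 (within the scatter) in this assay, so methyl can stand in for chlorine on this ring without a change that stands clear of the scatter. The step of a number 25 percentage points higher from compound 1 to compound 4 (beyond the scatter) places the 3,5-dimethylphenyl group, like the 3,5-dichlorophenyl group, clearly above 4-cyanophenyl. Nothing available explains these results.

From the compounds shown here alone, how a plain phenyl, or a phenyl carrying an amine or a carboxylic acid, would fare on this sulfur remains open. So does whether 3,5-dimethylphenyl would match 3,5-dichlorophenyl with chloro in place of methyl on the core.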